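The source may hold more compounds than are shown below. What is called first, only, known or untested is meant among the compounds shown, and "the series" means these compounds.

In a functional assay on SW480 cells (Homo sapiens) for antiproliferative activity, read by MTT assay, with a stated time of 48 h (a lower number here means a stronger inhibitor, a higher number a weaker inhibitor), compound 1 `CCCC(CCO)n1cnc2c(Cl)nc(F)nc21` gives 17200 nM. Compound 2 `CCCC(CCO)n1cnc2c(Cl)ncnc21` differs from compound 1 only by hydrogen in place of fluoro on an aromatic carbon. For compound 2 this assay reports only a limit, > 50000 nM. That change made an at least 2.9-fold higher number from compound 1 to compound 2 (0.46 log units; beyond the scatter), and the size of the step cannot be read beyond (the limit of > 50000 nM in this assay, at which 1 of the 3 values shown sits). Compound 3 `CCCCC(CCO)n1cnc2c(Cl)nc(F)nc21` differs from compound 1 by methyl in place of hydrogen on a saturated chain carbon, four bonds along the chain from an aromatic nitrogen; in this assay compound 3 gives 13200 nM, which is a 1.3-fold lower number from compound 1 to compound 3 (0.11 log units; within the scatter). Compound 4 `CCCCC(CCO)n1cnc2c(Cl)ncnc21` is not yet measured. It stands to compound 3 as compound 2 stands to compound 1: the change is hydrogen in place of fluoro on an aromatic carbon, and the place of the change reads the same word for word, so this is the same change, made twice among these four compounds. The step from compound 3 to compound 4 is expected to be about as large, or at least as large, as the measured one, since compound 3 is within the scatter of compound 1 and the change made an at least 2.9-fold higher number from compound 1 to compound 2 (0.46 log units; beyond the scatter); the expected step is a 3.4-fold higher number from compound 3 to compound 4 (0.53 log units; beyond the scatter). Compound 4 is therefore estimated at 45000 nM, between 25000 nM and 90000 nM, and this assay may well report only a limit for it.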

Compound 4, half-maximal inhibitory concentration: > 50000 nM
Compound 4: no number, only a limit; the forecaster's own chance of this, stated with the estimate: 60%; middle value at least 1.1-fold (0.04 log units) away from the limit.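

In this assay compound 4 is reported as > 50000 nM and that is a limit, not a number. Hydrogen in place of fluoro on an aromatic carbon thus goes the same way on the second core as on the first, with an at least 3.7-fold higher number from compound 3 to compound 4 (0.57 log units; beyond the scatter) and with both compounds that lack the fluoro group ending at a limit, so the step between those two cannot be read. This shows that the direction of the change carries over between these two closely related cores, but not that its size does, and two cores are no basis for a rule across the series: the same change on two cores in this assay, an at least 2.9-fold higher number (0.46 log units; beyond the scatter) from compound 1 to compound 2 and an at least 3.7-fold higher number (0.57 log units; beyond the scatter) from compound 3 to compound 4; the limit leaves it open whether they differ.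

The compounds shown leave open whether an amine or a methoxy group on the aromatic carbon between two ring nitrogen atoms would keep the numbers of compound 1 and compound 3 or lower them. They also leave open whether a longer chain than that of compound 3 would change the number at all.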